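The compounds below may be only part of what the source reports. "The series", "measured", "known", "first", "only" and "open" are said of these compounds alone.

Of the compounds shown here, three on a shared core have numbers so far. In a functional assay on HCT-116 cells (Homo sapiens) for cytotoxicity, read by sulforhodamine B assay, with a stated time of 24 h (a higher number here means a weaker inhibitor, a lower number a stronger inhibitor), compound 1 (`N=c1oc2ccccc2cc1C(=O)N/N=C1\C(=O)Nc2ccc(S(=O)(=O)N3CCOCC3)cc21`) gives 6750 nM and compound 2 (`COc1ccc(-c2c(C#N)c(N)n(/N=C3\C(=O)Nc4ccc(S(=O)(=O)N5CCOCC5)cc43)c(=O)c2C#N)cc1`) gives 18100 nM while compound 3 (`Cc1ccc(S(=O)(=O)N/N=C2\C(=O)Nc3ccc(S(=O)(=O)N4CCOCC4)cc32)cc1`) gives 23400 nM as its reading. Compound 3 sits level with compound 2, within the scatter, and its number is higher than that of compound 1 by a gap beyond the scatter.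

For the measured compounds named here, the next compound is compound 4 (`O=C1Nc2ccc(S(=O)(=O)N3CCOCC3)cc2/C1=N/Nc1ccccc1`), with phenyl in place of (4-methylphenyl)sulfonyl on an amine nitrogen as the only change from compound 3. Going by the values given here, no measured pair differs in one place, so the series gives no direct reading on this change. Among the compounds with values here, the basis for an expectation is thin: compound 1 at 6750 nM shows that the shared core can carry a lower number than compound 3 at 23400 nM does, and no measured compound carries the phenyl group. In this assay a modest step towards a lower number is expected, of a size near the edge of the scatter. The estimated change is a 2.0-fold lower number from compound 3 to compound 4 (0.29 log units; within the scatter) as the expected outcome. For compound 4 the estimated value is 12000 nM with an expected range from 4000 nM to 35000 nM for a single measurement.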

Compound 4, half-maximal inhibitory concentration: 10500 nM
Compound 4: middle estimate off by 1.1-fold (0.06 log units), on the high side; the measured number falls inside the stated range.
By their numbers in this assay, from the lowest: compounds 1, 4, 2 and 3 (each within the scatter of the next, the first and the last beyond it).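

In this assay, the series now has its first direct reading at the amine nitrogen whose other neighbour is a double-bonded nitrogen: phenyl in place of (4-methylphenyl)sulfonyl gives a 2.2-fold lower number from compound 3 to compound 4 (0.35 log units; beyond the scatter), a modest step. At this nitrogen, the (4-methylphenyl)sulfonyl group can therefore be given up without a rise in the number, even though the phenyl that enters has fewer heavy atoms, no double bonds outside aromatic rings and no hydrogen-bond acceptors. No measurement shown here accounts for the size or direction of this step.

The change replaces the sulfonyl link and removes the methyl group together, so this single pair cannot assign the step to either alteration; phenylsulfonyl or 4-methylphenyl at the same nitrogen would separate the two. Also open, going by these compounds, is whether the phenyl of compound 4 can carry further substitution in this assay, for example a methoxy group, an amine or a carboxylic acid, and whether any of these would move the number beyond the scatter.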